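Bromo in place of hydrogen: expected cytotoxicity of compound 3

The source may report more compounds than this note shows. Statements on the series, on what has been measured and on what is new or still open speak of the compounds shown alone.

Compound 1 `Cn1c(SCc2ccccc2)nnc1-c1cc([N+](=O)[O-])cc([N+](=O)[O-])c1` — > 30000 nM
Compound 2 `CCCCCCn1c(SCc2ccccc2)nnc1-c1cc([N+](=O)[O-])cc([N+](=O)[O-])c1` — > 30000 nM

Compound 1 was tested in an ADME assay on HepG2 cells (Homo sapiens) for cytotoxicity, with a stated time of 48 h; a lower number here means a stronger inhibitor, a higher number a weaker inhibitor. In this assay compound 1 gives only a limit, > 30000 nM. Compound 2 in this assay also gives only a limit, > 30000 nM. Going by the values given here, the one measured step, a step that the two limits leave unreadable from compound 1 to compound 2, is therefore not readable in size or direction; what the two values share is the limit of > 30000 nM in this assay, at which 2 of the 2 values shown sit.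

Compound 3 `Cn1c(SCc2ccc(Br)cc2)nnc1-c1cc([N+](=O)[O-])cc([N+](=O)[O-])c1` differs from compound 1 by bromo in place of hydrogen on an aromatic carbon. Among the compounds with values here, no measured step touches this part of the molecule, and the only step known, from compound 1 to compound 2, is itself unreadable, so nothing in the data points to a gain or loss beyond the scatter. Compound 3 is accordingly expected to sit at the same limit, with the step that the limit leaves unreadable from compound 1 to compound 3 estimated as none beyond the scatter. The estimate for compound 3 in this assay is 40000 nM, within a range from 15000 nM to 120000 nM.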

Compound 3, half-maximal inhibitory concentration: > 30000 nM
Compound 3 ended at the assay's limit (the forecaster's own chance of this, stated with the estimate: 80%); the middle value does not contradict the limit.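

Compound 3 and compound 1 both give only a limit in this assay, so no step between them can be read: the limit of > 30000 nM in this assay, at which 3 of the 3 values shown sit.

The compounds shown leave open whether bromo or pentyl in place of hydrogen alters cytotoxicity at all, and what any compound's actual value is.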